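A few compounds are considered here, and "the series" means these few. Any claim that something is new, unique, unknown or untested is made for them only; others in the source may bear on it.

Measured compounds: compound 1 `NC[C@@H]1CCCc2cc(S(=O)(=O)c3cc[nH]c3)ccc21` gives 0.316 nM; compound 2 `CNC[C@@H]1CCCc2cc(S(=O)(=O)c3cc[nH]c3)ccc21` gives 0.159 nM; compound 3 `CNS(=O)(=O)NC[C@@H]1CCCc2cc(S(=O)(=O)c3cccc(F)c3)ccc21` gives 1 nM, all in an assay on isolated protein for displacement of a labelled ligand from 5-hydroxytryptamine receptor 6 (Homo sapiens); a lower number here means a stronger inhibitor, a higher number a weaker inhibitor.

Compound 3 has the highest number of the three in this assay; compound 1 sits closest to it and compound 2 furthest, and both gaps from compound 3 are beyond the scatter, so compound 3 is the weakest of the measured set.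

Compound 4 `O=S(=O)(c1cccc(F)c1)c1ccc2c(c1)CCC[C@H]2CN1CCCS1(=O)=O` differs from compound 3 in one place: a group of 7 heavy atoms (3 carbon, 1 nitrogen, 2 oxygen, 1 sulfur; one five-membered non-aromatic ring with 2 hetero atoms) in place of a group of 6 heavy atoms (1 carbon, 2 nitrogen, 2 oxygen, 1 sulfur; no ring), on a saturated chain carbon bound to a saturated ring carbon. Nothing measured speaks directly to this change. Among the compounds with values here, the only step recorded in the set, a 2.0-fold lower number from compound 1 to compound 2 (0.30 log units; within the scatter), concerns a methyl in place of hydrogen on an amine nitrogen in the shared core and stays within the scatter; it shows that a small change on the chain carbon bound to the saturated ring carbon can leave the number nearly unchanged, but the change from compound 3 to compound 4 is larger and of a different kind. Within the data shown here, with no direct precedent, the expectation for compound 4 is a step of a 1.5-fold higher number from compound 3 to compound 4 (0.18 log units; within the scatter) that is not clearly beyond the scatter, with a wide range. The estimate for compound 4 in this assay is 1.5 nM, between 0.4 nM and 6 nM.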

Compound 4, inhibition constant: 31.6 nM
Compound 4: middle estimate off by 21-fold (1.32 log units), on the low side; measured number above the stated range.
By their numbers in this assay, from the lowest: compounds 2 and 1 (each within the scatter of the next); then compound 3; then compound 4.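

In this assay, within the data shown here, the step of a 32-fold higher number from compound 3 to compound 4 (1.50 log units; beyond the scatter) shows that a saturated chain carbon bound to a saturated ring carbon is not indifferent to the group it carries, something the only earlier step, a 2.0-fold lower number from compound 1 to compound 2 (0.30 log units; within the scatter), gave no sign of. The group that leaves and the group that enters are close in heavy-atom count and both have 2 hydrogen-bond acceptors and no net charge, so these counts alone do not keep the number in place; the visible differences are the five-membered non-aromatic ring and the fall from 2 hydrogen-bond donors to 0 hydrogen-bond donors. No supporting measurement bears on why the number rises so far.

The compounds shown leave open whether the ring or the missing donors matter more, a question that an open-chain N-methyl methanesulfonamide or a five-membered lactam at the same place could help to separate. They also leave open whether the same step would appear with the pyrrole-bearing sulfonyl of compound 1 and compound 2 in place of the fluorophenyl sulfonyl of compound 3 and compound 4.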